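The source may hold more compounds than are shown below. What is called first, only, known or untested is meant among the compounds shown, and "the series" means these compounds.

Measured compounds:
Compound 1, `CCOC(=O)c1c(-c2cccc(OC)c2)[nH]c2cc(OC)ccc2c1=O`, in an ADME assay on Raji cells (Homo sapiens) for cytotoxicity, read by luminescence, with a stated time of 72 h; a higher number here means that more compound is needed for the effect, a lower number that less compound is needed: > 21500 nM
Compound 2, `CCOC(=O)c1c(-c2cccc(Oc3ccccc3)c2)[nH]c2cc(OC)ccc2c1=O`, in this assay: > 21500 nM
Compound 3, `CCOC(=O)c1c(-c2cccc(OC)c2)[nH]c2cc(F)cc(F)c2c1=O`, in this assay: > 21500 nM.

For compound 1 the value is a limit of the assay rather than a number. For compound 2 the value is likewise a limit. For compound 3 the value is again a limit.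

Compound 2 differs from compound 1 by phenyl in place of methyl on an oxygen on an aromatic ring, and the step that the two limits leave unreadable from compound 1 to compound 2. Compound 3 and compound 1 differ in more than one place, so the difference between the two cores is not broken down here.

Compound 4, `CCOC(=O)c1c(-c2cccc(Oc3ccccc3)c2)[nH]c2cc(F)cc(F)c2c1=O`, has not yet been measured. It differs from compound 3 by phenyl in place of methyl on an oxygen on an aromatic ring, the same change seen from compound 1 to compound 2, and the surroundings of the place are described in the same words. The earlier step gives no size to lean on, since (the limit of > 21500 nM in this assay, at which 3 of the 3 values shown sit).

The expected step is a step that the limit leaves unreadable from compound 3 to compound 4, resting on the same change having left compound 2 at a limit. For compound 4 the estimate is 30000 nM, with a range from 15000 nM to 80000 nM, and most likely the assay again reports only a limit.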

Compound 4, half-maximal effective concentration: > 21500 nM
Compound 4: no number, only a limit (the forecaster's own chance of this, stated with the estimate: 85%); the middle value does not contradict the limit.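

In this assay compound 4 gives > 21500 nM, which is a limit and not a number. Compound 3 also stands at a limit, so no size can be read for the change from methoxy to phenoxy between compound 3 and compound 4. The compounds shown leave open how much of any of the four would be needed for the effect.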